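Working notes: tert-butyl in place of propoxy

A few compounds are considered here, and "the series" means these few. Any claim that something is new, unique, unknown or untested is made for them only; others in the source may bear on it.

Compound 1 `CSc1ccc(S(=O)(=O)NC(=O)Nc2ccc(Cl)cc2)s1` and compound 2 `CCCOc1ccc(S(=O)(=O)NC(=O)Nc2ccc(Cl)cc2)s1` share one core and differ at a single aromatic carbon. In a functional assay on the whole organism (6C3HED cells, Mus musculus) for inhibition, at a dose of 300 mg/kg by the oral route (on this read-out higher numbers stand for more inhibition at the one dose given (going by the name of the read-out) and lower numbers for less inhibition), compound 1 gives 62%, and compound 2 gives 63%. The step of a number 1 percentage points higher from compound 1 to compound 2 (within the scatter) lies within the scatter, so the two compounds are not distinguished on this read-out; compound 2 holds the larger of the two numbers shown, but by a margin that carries no weight. Compound 3 `CC(C)(C)c1ccc(S(=O)(=O)NC(=O)Nc2ccc(Cl)cc2)s1` is not yet measured; its difference from compound 2 is tert-butyl in place of propoxy on an aromatic carbon. Within the data shown here, the one measured step that concerns this position is a number 1 percentage points higher from compound 1 to compound 2 (within the scatter), where an exchange of the group at the same aromatic carbon left the read-out unchanged beyond the scatter. Compound 3 is therefore expected to show a number 3 percentage points lower from compound 2 to compound 3 (within the scatter), with no move beyond the scatter. The estimate for compound 3 in this assay is 60%, within a range from 45% to 75%.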

Compound 3, a percentage reported as inhibition, in the whole organism at one dose (the size of the read-out at that dose, not a potency): 10%
Beside the measured number, compound 3's estimate is 50 percentage points above it; measured number below the stated range.
By their numbers in this assay, from the lowest: compound 3; then compounds 1 and 2 (each within the scatter of the next).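

The aromatic carbon next to the ring sulfur is not indifferent to its group in this assay: tert-butyl gives a number 53 percentage points lower from compound 2 to compound 3 (beyond the scatter) and a number 52 percentage points lower from compound 1 to compound 3 (beyond the scatter), although the exchange of methylsulfanyl for propoxy gave no step beyond the scatter. Propoxy and tert-butyl both have 4 heavy atoms, so that count does not separate them; the printed differences are an oxygen in propoxy, with its 1 hydrogen-bond acceptor, against 0 in the all-carbon tert-butyl. No measurement at hand explains the drop.

On these data alone, it remains open whether the drop is specific to tert-butyl or extends to other all-carbon groups at this position, such as isopropyl or a straight butyl chain. As far as these compounds go, it is also open how an amine or a carboxylic acid at the same carbon would read out in this assay.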